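The source may report more compounds than this note shows. Statements on the series, on what has been measured and on what is new or still open speak of the compounds shown alone.

In a functional assay on a cell-free system (plasma, Homo sapiens), with a stated time of 3 min (a higher number here means a weaker inhibitor, a lower number a stronger inhibitor), compound 1 (`O=C(NCc1cc(Cl)ccc1-n1cnnn1)[C@@H]1C[C@@H]2C[C@@H]2N1C(=O)[C@H](O)CC1CC1`) gives 1700 nM, level at the digits shown with compound 3 (`CC(C)(C)[C@@H](O)C(=O)N1NCC[C@H]1C(=O)NCc1cc(Cl)ccc1-n1cnnn1`) at 1700 nM. Compound 2 (`O=C(NCc1cc(Cl)ccc1-n1cnnn1)[C@@H]1C[C@H]2C[C@H]2N1C(=O)[C@H](O)CC1CC1`) gives 850 nM. This pair is useful to compare on account of the fact that compounds 1 and 2 differ only in the configuration as drawn. The step is a 2.0-fold lower number from compound 1 to compound 2 (0.30 log units; within the scatter), so the two compounds cannot be told apart in this measurement.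

Compound 4 (`O=C(NCc1cc(Cl)ccc1-n1cnnn1)[C@@H]1C[C@@H]2C[C@@H]2N1C(=O)[C@H](O)Cc1ccccn1`) keeps the core of compound 1 but carries pyridin-2-yl in place of cyclopropyl, on a saturated chain carbon, two bonds along the chain from a carbonyl carbon and an oxygen on a saturated carbon. The counted difference is pyridin-2-yl in place of cyclopropyl on a saturated chain carbon, two bonds along the chain from a carbonyl carbon and an oxygen on a saturated carbon. Read one bond further out, this is cyclopropylmethyl changing to (pyridin-2-yl)methyl.

For the measured compounds named here, no measured step makes this change or anything close to it. Going by the values given here, the one measured step, a 2.0-fold lower number from compound 1 to compound 2 (0.30 log units; within the scatter), concerns configuration only and offers no guide to the size or direction of a change of group. The expectation therefore stays anchored on compound 1 at 1700 nM, with no shift beyond the scatter and a wide margin on either side. The estimated step is a 1.4-fold lower number from compound 1 to compound 4 (0.15 log units; within the scatter). Compound 4 is expected at about 1200 nM, with an estimated range from 300 nM to 4500 nM.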

Compound 4, half-maximal inhibitory concentration: 1000 nM
Compound 4: middle estimate off by 1.2-fold (0.08 log units), on the high side; measured number inside the range.
By their numbers in this assay, from the lowest: compounds 2, 4, 1 and 3 (each within the scatter of the next).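

In this assay, putting pyridin-2-yl in place of cyclopropyl on this saturated chain carbon, two bonds along the chain from a carbonyl carbon and an oxygen on a saturated carbon, gives a 1.7-fold lower number from compound 1 to compound 4 (0.23 log units; within the scatter), so this measurement cannot tell the two compounds apart. This is the only change of group at this position among the compounds shown, and it is not a small one on paper: a three-membered ring of carbon only, with 3 heavy atoms and no hydrogen-bond acceptor, gives way to a six-membered aromatic ring with 6 heavy atoms and 1 hydrogen-bond acceptor, yet the number stays within the scatter. Nothing measured here explains why the two compounds read alike.

The compounds shown leave open whether another kind of group at this position, such as an amine, a carboxylic acid or a longer chain, would move the number beyond the scatter, and whether a plain phenyl ring would read like pyridin-2-yl. They also leave open whether the same exchange of groups would read alike on the core of compound 2, with its different configuration as drawn.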